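A few compounds are considered here, and "the series" means these few. Any claim that something is new, unique, unknown or untested is made for them only; others in the source may bear on it.

Measured so far in a functional assay (Cavia porcellus) with sulfonylurea receptors; K-ATP channels (Homo sapiens) as the target; on this read-out higher numbers stand for weaker inhibition and lower numbers for stronger inhibition:
compound 1 `CC(O)(C(=O)Nc1ccc(S(=O)(=O)c2ccccc2F)cc1)C(F)(F)F`: 1300 nM
compound 2 `CC(O)(C(=O)Nc1ccc(S(=O)(=O)c2ccc(C#N)cc2)cc1)C(F)(F)F`: > 30000 nM (a limit of the assay)
compound 3 `Cc1ccc(S(=O)(=O)c2ccc(NC(=O)C(C)(O)C(F)(F)F)cc2)cc1`: > 30000 nM (a limit of the assay)

Compound 3 stands at a limit in this assay, not at a read number. Compound 2 sits at the same limit (the limit of > 30000 nM in this assay, at which 2 of the 3 values shown sit). Only compound 1 has a read value.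

Compound 4 `CC(O)(C(=O)Nc1ccc(S(=O)(=O)c2cnccn2)cc1)C(F)(F)F` arises from compound 3 by pyrazin-2-yl in place of 4-methylphenyl on a sulfonyl sulfur. Among the compounds with values here, no measured step puts a heteroaryl on the sulfonyl sulfur. The steps at this position are an at least 23-fold higher number from compound 1 to compound 3 (1.36 log units; beyond the scatter) and an at least 23-fold higher number from compound 1 to compound 2 (1.36 log units; beyond the scatter): both rings tried in place of 2-fluorophenyl pushed the number to the limit. The step that the two limits leave unreadable from compound 2 to compound 3 cannot be read between two limits. Whether pyrazin-2-yl behaves like 2-fluorophenyl or like the two limit compounds is not readable from these three.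

Compound 4 is expected to give about 15000 nM in this assay, in the range 2000 nM to 60000 nM. The expected step of an at least 2.0-fold lower number from compound 3 to compound 4 (0.30 log units; that floor lies within the scatter) runs against a limit, so its size is not readable.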

Compound 4, half-maximal inhibitory concentration: 12000 nM
For compound 4 the middle estimate is 1.3-fold (0.10 log units) above the measured one, and the stated range covers the measured number.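

In this assay, pyrazin-2-yl is a replacement for 2-fluorophenyl on the sulfonyl sulfur that does not end at the limit, giving an at least 2.5-fold lower number from compound 3 to compound 4 (0.39 log units; beyond the scatter) and an at least 2.5-fold lower number from compound 2 to compound 4 (0.39 log units; beyond the scatter). Compound 2 and compound 3 stand at a limit of the assay, so both steps are floors and their full size stays unread: the limit of > 30000 nM in this assay, at which 2 of the 4 values shown sit. The change from 2-fluorophenyl still gives a 9.2-fold higher number from compound 1 to compound 4 (0.97 log units; beyond the scatter), so compound 1 keeps the lowest number of the four and the heteroaryl recovers only part of the ground lost at this position.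

The compounds shown do not tell whether the ring nitrogens of pyrazin-2-yl or the removal of the 4-methylphenyl or 4-cyanophenyl ring accounts for the step. Going by these compounds, how an amine in place of the ring on the sulfonyl sulfur would read also stays open.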